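The source may report more compounds than this note shows. Statements on the series, on what has been measured and on what is new or still open speak of the compounds shown alone.

Working notes on a small set sharing one core. Compound 1 `CC1=C(CCC(=O)OCCCCOc2no[n+]([O-])c2S(=O)(=O)c2ccccc2)C(=O)c2c(O)cccc2C1=O` serves as the reference. Compound 2 `CC1=C(C(C)CC(=O)OCCCCOc2no[n+]([O-])c2S(=O)(=O)c2ccccc2)C(=O)c2c(O)cccc2C1=O` differs from compound 1 in one place: methyl in place of hydrogen on a saturated chain carbon bound to a double-bonded ring carbon and a saturated chain carbon. Compound 3 `CC1=C(CCC(=O)OCCCOc2no[n+]([O-])c2S(=O)(=O)c2ccccc2)C(=O)c2c(O)cccc2C1=O` carries the same core, but the difference between the core of compound 1 and the core of compound 3 is not broken down here. Compound 4 `CC1=C(C(C)CC(=O)OCCCOc2no[n+]([O-])c2S(=O)(=O)c2ccccc2)C(=O)c2c(O)cccc2C1=O` differs from compound 3 in one place: methyl in place of hydrogen on a saturated chain carbon bound to a double-bonded ring carbon and a saturated chain carbon. The two place lines agree word for word, so the change made from compound 3 to compound 4 is the same change as that made from compound 1 to compound 2; it occurs twice in the set.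

In a functional assay on HepG2 cells (Homo sapiens) for inhibition, read by MTT assay, with a stated time of 72 h (on this read-out lower numbers stand for stronger inhibition and higher numbers for weaker inhibition), compound 1 gives 3330 nM. Compound 2 gives 4240 nM in this assay, and the step of a 1.3-fold higher number from compound 1 to compound 2 (0.10 log units; within the scatter). Compound 3 gives 6790 nM in this assay; that number stands apart from compound 1 beyond the scatter, while compound 3 and compound 2 lie within the scatter of each other.

Among the measured compounds shown here, the expectation for compound 4 rests on the one measured instance of the change, where the step of a 1.3-fold higher number from compound 1 to compound 2 (0.10 log units; within the scatter) was small. Applying a step of like size to compound 3, the expected step is a 1.3-fold higher number from compound 3 to compound 4 (0.10 log units; within the scatter). Compound 4 is therefore estimated to give 8500 nM in this assay, with an expected range from 4800 nM to 15000 nM.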

Compound 4, half-maximal inhibitory concentration: 4320 nM
Compound 4: middle estimate off by 2.0-fold (0.29 log units), on the high side; measured number outside the range, below it.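

In this assay, methyl in place of hydrogen on a saturated chain carbon bound to a double-bonded ring carbon and a saturated chain carbon gives a 1.6-fold lower number from compound 3 to compound 4 (0.20 log units; within the scatter). Set beside the earlier instance of the same change, the new step does not stand apart from it: the same change on two cores in this assay, a 1.3-fold higher number (0.10 log units; within the scatter) from compound 1 to compound 2 and a 1.6-fold lower number (0.20 log units; within the scatter) from compound 3 to compound 4, 2.0-fold (0.30 log units) apart, within the scatter of two such steps. On these two cores, the change therefore carries over as one whose step stays within the scatter each time, but the opposite directions of the two steps carry no weight, and the pairs do not show that the core alters the outcome of the change or that a step of any particular size or direction can be relied on for another core.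

The compounds shown leave open whether a group other than methyl on the same saturated chain carbon, such as ethyl, a hydroxyl group or fluorine, would give a step beyond the scatter. Among the compounds shown here, they also leave open how the change would behave on a core with a longer chain, since only two pairs, both read in this one cell assay, bear on the question.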